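Fluorophenylsulfonyl replaces benzyl on the aromatic nitrogen

This account rests on a few compounds, and the source may have more. Where it says the series, first, only, none or still open, it means among the compounds named here.

Compound 1 `COc1ccc(S(=O)(=O)N2CCc3cccc(NS(=O)(=O)c4ccc([N+](=O)[O-])cc4)c32)cc1`: 933 nM
Compound 2 `COc1ccc(C(=O)Nc2cccc3c2N(S(=O)(=O)c2ccc(OC)cc2)CC3)cc1`: 1600 nM
Compound 3 `COc1ccc(S(=O)(=O)N2CCc3cccc(NCc4ccccc4)c32)cc1`: > 10000 nM

In a functional assay on MKN-45 cells (Homo sapiens) for cytotoxicity (a higher number here means a weaker inhibitor, a lower number a stronger inhibitor), compound 1 gives 933 nM and compound 2 gives 1600 nM. Compound 3 reaches only > 10000 nM, which is a limit of the assay and not a number. It therefore stands at the weak end of the three, at the limit of > 10000 nM in this assay, at which 1 of the 3 values shown sits. Going by the values given here, the single measured step that touches compound 3 is an at least 6.2-fold higher number from compound 2 to compound 3 (0.79 log units; beyond the scatter), a move toward weaker inhibition when an aryl carbonyl on that nitrogen gives way to benzyl.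

Compound 4 `COc1ccc(S(=O)(=O)N2CCc3cccc(NS(=O)(=O)c4ccc(F)cc4)c32)cc1` undoes that kind of exchange: (4-fluorophenyl)sulfonyl in place of benzyl on a nitrogen on an aromatic ring. Among the measured compounds, compound 1 stands structurally nearest to compound 4. In this assay compound 1 gives 933 nM. The benzyl-bearing compound 3, by contrast, sits at a limit. The expected step of an at least 6.6-fold lower number from compound 3 to compound 4 (0.82 log units; beyond the scatter) is accordingly estimated to run toward stronger inhibition, well beyond the scatter, given that compound 1 gives 933 nM and compound 2 gives 1600 nM. Compound 4 is estimated at 1500 nM, with a range from 500 nM to 5000 nM.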

Compound 4, half-maximal inhibitory concentration: 890 nM
The estimate for compound 4 lay 1.7-fold (0.23 log units) above the measured number; the measured number falls inside the stated range.
By their numbers in this assay, from the lowest: compounds 4, 1 and 2 (each within the scatter of the next). At a limit, above all of these: compound 3.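

In this assay, (4-fluorophenyl)sulfonyl in place of benzyl on a nitrogen on an aromatic ring gives an at least 11-fold lower number from compound 3 to compound 4 (1.05 log units; beyond the scatter), showing that a sulfonyl link at this nitrogen can match the carbonyl link of compound 2 while benzyl does not. As far as these compounds go, compound 3 remains a limit of the assay and not a number, so the true size of this step is unknown: the limit of > 10000 nM in this assay, at which 1 of the 4 values shown sits. The aryl group on the sulfonyl appears to matter little here, since fluoro in place of nitro on an aromatic carbon gives a 1.0-fold lower number from compound 1 to compound 4 (0.02 log units; within the scatter), and the exchange of (4-methoxyphenyl)carbonyl gives a 1.8-fold lower number from compound 2 to compound 4 (0.25 log units; within the scatter).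

The compounds shown leave open whether an amine or a carboxylic acid on that aromatic ring would fit as well as fluoro or nitro. They also leave open whether a methylsulfonyl group or a longer alkyl chain on the sulfonyl would hold the number without any aromatic ring there.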